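The source may report more compounds than this note shows. Statements on the series, on what has been measured and on what is new or still open speak of the compounds shown alone.

In an assay on HeLa cells for displacement of a labelled ligand from 5-hydroxytryptamine receptor 6 (Homo sapiens) (a lower number here means a stronger inhibitor, a higher number a weaker inhibitor), compound 2, whose structure is `Cc1ccc(Nc2nc3ccc(C)cn3c(=N)c2S(=O)(=O)c2ccccc2)nc1`, gives 60 nM. Compound 1, with the structure `CSc1nc2ccccn2c(=N)c1S(=O)(=O)c1ccc2ccccc2c1`, gives 59 nM, and the two values lie within the scatter of each other, so neither stands apart. Compound 3, `CSc1nc2ccc(C)cn2c(=N)c1S(=O)(=O)c1ccccc1`, has not yet been measured; it differs from compound 2 by methylsulfanyl in place of (5-methylpyridin-2-yl)amino on an aromatic carbon. Compound 1 shows that a methylsulfanyl group at this position is compatible with a value of 59 nM, so only a small step is expected from compound 2 to compound 3, a 1.8-fold higher number from compound 2 to compound 3 (0.26 log units; within the scatter), toward a weaker number. For compound 3 the expected value in this assay is 110 nM, within a range from 35 nM to 400 nM.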

Compound 3, half-maximal inhibitory concentration: 1.3 nM
Compound 3: the middle estimate sits 85-fold (1.93 log units) above what was measured, outside the stated range (below it).
By their numbers in this assay, from the lowest: compound 3; then compounds 1 and 2 (each within the scatter of the next).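

Putting methylsulfanyl in place of (5-methylpyridin-2-yl)amino on this aromatic carbon gives a 46-fold lower number from compound 2 to compound 3 (1.66 log units; beyond the scatter) in this assay, so the choice of group here matters greatly, which compounds 1 and 2 could not show because they differ in more than one place. The pyridine ring and its amino link are clearly not needed for a low number. Nothing available explains the size of this step. As far as these compounds go, whether the sulfur, the shorter group or the loss of the ring counts most remains open. A methoxy group, a plain amine or a longer chain such as ethylsulfanyl on this carbon would help to separate these.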